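The source may report more compounds than this note shows. Statements on the series, on what has been measured and on what is new or still open speak of the compounds shown alone.

In a functional assay on SMMC-7721 cells (Homo sapiens) for cytotoxicity, read by MTT assay, with a stated time of 72 h (on this read-out higher numbers stand for weaker inhibition and lower numbers for stronger inhibition), compound 1, with the structure `O=C(CSC(=S)N[C@H]1CCOC1=O)Nc1ccccc1`, is reported only as a limit of the assay, > 128000 nM. Compound 2, with the structure `O=C(CSC(=S)N[C@H]1CCOC1=O)Nc1ccc(O)cc1`, carries a hydroxy in place of a hydrogen on an aromatic carbon, and its result in this assay is likewise a limit, > 128000 nM. The step that the two limits leave unreadable from compound 1 to compound 2 therefore cannot be read. Compound 3, with the structure `CCSC(=S)N[C@H]1CCOC1=O`, is the smallest of the three, and in this assay compound 3 also gives only a limit, > 128000 nM. Among the compounds with values here, compound 3 thus stands at the limit of > 128000 nM in this assay, at which 3 of the 3 values shown sit, so nothing in the numbers so far separates it from compound 1 or compound 2.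

Compound 4, with the structure `CCCCCCSC(=S)N[C@H]1CCOC1=O`, differs from compound 3 by butyl in place of hydrogen on a saturated chain carbon, two bonds along the chain from a sulfur. Within the data shown here, no measured step touches this chain: the only recorded step is the one from compound 1 to compound 2, and it was left unreadable by two limits. The measured compounds therefore give no direction and no size for this change, and the most that can be said is that every neighbour of compound 4 sits at the limit. The expectation for compound 4 is accordingly a step that the limit leaves unreadable from compound 3 to compound 4 in this assay, with the result most likely reported again as a limit, and the estimate is 150000 nM, within a range from 60000 nM to 500000 nM.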

Compound 4, half-maximal inhibitory concentration: > 128000 nM
Compound 4: a limit, no number; the forecaster's own chance of this, stated with the estimate: 75%; the middle value is on the limit's open side.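

In this assay compound 4 gives > 128000 nM, which is a limit of the assay and not a number, so the step from compound 3 to compound 4 cannot be read. All the compounds now sit together: the limit of > 128000 nM in this assay, at which 4 of the 4 values shown sit.

The compounds shown leave open whether the butyl, or any other change to the shared core, alters the result in this assay.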